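This account rests on a few compounds, and the source may have more. Where it says the series, first, only, none or still open, it means among the compounds named here.

Measured so far in this series:
Compound 1, `COc1cccc(-c2nc(SC)nc3sc(C(=O)NCc4ccccc4)c(N)c23)c1`, gives 7.8%.
Compound 2, `CCOC(=O)c1sc2nc(SC)nc(-c3cccc(OC)c3)c2c1N`, gives 4.2%.
Compound 3, `COc1cccc(-c2nc(SC)nc3sc(C(=O)N(C)C(C)(C)C)c(N)c23)c1`, gives 47.8%.

In a functional assay on HEK293 cells for agonist activity at lutropin-choriogonadotropic hormone receptor (Homo sapiens), read by cAMP accumulation (a lower number here means a smaller maximal response, a higher number a larger maximal response), compound 3 stands highest of the three numbers. Compound 1 and compound 2 sit close together, since a number 3.6 percentage points lower from compound 1 to compound 2 (within the scatter) lies within the scatter. The two steps leading to compound 3 are both large: a number 40 percentage points higher from compound 1 to compound 3 (beyond the scatter) and a number 43.6 percentage points higher from compound 2 to compound 3 (beyond the scatter). On these numbers the group on the carbonyl carbon is the one place that has moved the response strongly, and only methyl(tert-butyl)amino has given a high value.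

Compound 4 is `COc1cccc(-c2nc(SC)nc3sc(C(=O)NCC#N)c(N)c23)c1`. Compared with compound 3 the change is (cyanomethyl)amino in place of methyl(tert-butyl)amino on a carbonyl carbon. Both measured steps that bear on this position were large upward moves into methyl(tert-butyl)amino; compound 4 moves away from that group again, toward an amino group like the benzylamino of compound 1, which gave a low value. The step is therefore expected to be downward and beyond the scatter, of the order of a number 37.8 percentage points lower from compound 3 to compound 4 (beyond the scatter). For compound 4 the expected value is 10%, with a range from 2% to 30%.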

Compound 4, largest response reached (reported as efficacy), in percent of the reference or control that the assay uses: 20.3%
Compound 4: middle estimate off by 10.3 percentage points, on the low side; the range from low to high includes it.
By their numbers in this assay, from the lowest: compounds 2 and 1 (each within the scatter of the next); then compound 4; then compound 3.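

In this assay, the group on the carbonyl carbon is no longer a simple choice between a low and a high response, as compound 4 takes an intermediate place: a number 27.5 percentage points lower from compound 3 to compound 4 (beyond the scatter), while a number 16.1 percentage points higher from compound 2 to compound 4 (beyond the scatter) and a number 12.5 percentage points higher from compound 1 to compound 4 (beyond the scatter). Going by these compounds alone, the last of these steps also shows that, with the amide hydrogen kept, the end of the chain on the nitrogen matters, as cyano in place of phenyl on a saturated chain carbon bound to an amide-type nitrogen moves the response beyond the scatter, so methyl(tert-butyl)amino is not the only group that lifts the value above that of compound 1. No measured evidence accounts for any of these differences.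

The compounds shown leave open whether the higher value of compound 3 follows from its methyl on the amide nitrogen or from its tert-butyl, which tert-butylamino or dimethylamino on the same carbonyl carbon would separate. They also leave open whether the gain of compound 4 over compound 1 depends on the nitrile itself, which an ethylamino or a 2-methoxyethylamino group at this place would test.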